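Second trifluoromethyl on the aryl of compound 2

The source may hold more compounds than are shown below. What is called first, only, known or untested is meant among the compounds shown, and "the series" means these compounds.

Three compounds sharing one core were tested in a functional assay on A375P cells (Homo sapiens) for antiproliferative activity, read by MTT assay, with a stated time of 24 h; on this read-out higher numbers stand for weaker inhibition and lower numbers for stronger inhibition. Compound 1 `O=C(Nc1ccc(-n2ccc3c(NC(=O)c4ccccc4)ncnc32)cc1)c1ccc(Cl)c(C(F)(F)F)c1` gives 2300 nM, compound 3 `O=C(Nc1ccc(-n2ccc3c(NC(=O)c4ccccc4)ncnc32)cc1)Nc1ccc(Cl)c(Cl)c1` gives 4000 nM, and compound 2 `O=C(Nc1ccc(-n2ccc3c(NC(=O)c4ccccc4)ncnc32)cc1)Nc1cccc(C(F)(F)F)c1` gives 9500 nM, the highest of the three numbers. The step of a 4.1-fold higher number from compound 1 to compound 2 (0.62 log units; beyond the scatter) and the step of a 2.4-fold lower number from compound 2 to compound 3 (0.38 log units; beyond the scatter) both lie beyond the scatter, while a 1.7-fold higher number from compound 1 to compound 3 (0.24 log units; within the scatter) does not.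

Compound 4 `O=C(Nc1ccc(-n2ccc3c(NC(=O)c4ccccc4)ncnc32)cc1)Nc1cc(C(F)(F)F)cc(C(F)(F)F)c1` differs from compound 2 by trifluoromethyl in place of hydrogen on an aromatic carbon. Within the data shown here, the only measured step on the same aromatic ring is a 2.4-fold lower number from compound 2 to compound 3 (0.38 log units; beyond the scatter), where a second substituent on that ring brought a modest fall in the number. Among the measured compounds shown here, no measured pair carries two trifluoromethyl groups on this ring, so the bearing of that step on compound 4 is indirect. It is therefore expected that compound 4 shows a modest fall, a 1.9-fold lower number from compound 2 to compound 4 (0.28 log units; within the scatter), with a range wide enough to include no change at all. The estimate for compound 4 in this assay is 5000 nM, between 1800 nM and 14000 nM.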

Compound 4, half-maximal inhibitory concentration: 9800 nM
The estimate for compound 4 lay 2.0-fold (0.29 log units) below the measured number; low and high end bracket the measured number.
By their numbers in this assay, from the lowest: compounds 1 and 3 (each within the scatter of the next); then compounds 2 and 4 (each within the scatter of the next).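

In this assay, trifluoromethyl in place of hydrogen on this aromatic carbon of compound 2 leaves the number unchanged within the scatter: a 1.0-fold higher number from compound 2 to compound 4 (0.01 log units; within the scatter). The modest fall seen in a 2.4-fold lower number from compound 2 to compound 3 (0.38 log units; beyond the scatter) therefore does not carry over to a second trifluoromethyl on this ring, and this position accepts that group with neither a readable gain nor a readable loss. No evidence on why the step is flat is available here.

The compounds shown leave open whether a different group on this carbon, such as an amine, a methoxy group or a single fluorine, would move the number. Also open, as far as these compounds go, is whether trifluoromethyl at this position would behave the same way on the aryl of compound 1, which sits directly on the carbonyl carbon.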